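The source may report more compounds than this note shows. Statements on the series, on what has been measured and on what is new or still open speak of the compounds shown alone.

Working notes on the series

Of the compounds shown here, three sharing one core have been measured in a functional assay on A549 cells (Homo sapiens) for antiproliferative activity, read by MTT assay, with a stated time of 72 h; a higher number here means a weaker inhibitor, a lower number a stronger inhibitor. Compound 1 `COc1ccc(N2CCN(C(=S)SCc3ccc4nc(N)nc(N)c4c3)CC2)cc1` gives 1590 nM, compound 2 `Cc1ccc(N2CCN(C(=S)SCc3ccc4nc(N)nc(N)c4c3)CC2)cc1` gives 2190 nM, and compound 3 `CC(=O)c1ccc(N2CCN(C(=S)SCc3ccc4nc(N)nc(N)c4c3)CC2)cc1` gives 2550 nM. Compound 2 stands second highest of the three numbers, with compound 3 nearest and compound 1 furthest; the step of a 1.2-fold higher number from compound 2 to compound 3 (0.07 log units; within the scatter) and the step of a 1.4-fold higher number from compound 1 to compound 2 (0.14 log units; within the scatter) both fall within the scatter, as does a 1.6-fold higher number from compound 1 to compound 3 (0.21 log units; within the scatter). On the numbers shown, the three measured compounds cannot be told apart.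

Compound 4 `Nc1nc(N)c2cc(CSC(=S)N3CCN(c4ccccn4)CC3)ccc2n1` has not yet been measured. Relative to compound 2 it carries one change: pyridin-2-yl in place of 4-methylphenyl on an amine nitrogen in a ring. The three measured steps each exchange one substituent on an aromatic carbon of a carbon-only ring; none replaces that ring itself, and none brings a ring nitrogen in. Within the data shown here, no measured step therefore bears directly on this change. What the measured steps do show is that three different groups on that ring left this assay unchanged beyond the scatter, which gives some ground to expect the same here, with wider uncertainty.

The expected value for compound 4 in this assay is 2500 nM, with a range from 1000 nM to 6500 nM. The estimated step of a 1.1-fold higher number from compound 2 to compound 4 (0.06 log units; within the scatter) is expected to stay within the scatter.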

Compound 4, half-maximal inhibitory concentration: 3960 nM
Compound 4: middle estimate off by 1.6-fold (0.20 log units), on the low side, and the stated range covers the measured number.
By their numbers in this assay, from the lowest: compounds 1, 2, 3 and 4 (each within the scatter of the next, the first and the last beyond it).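

In this assay, among these compounds, the new compound supplies what the earlier steps lacked, an exchange of the whole aromatic ring on the amine nitrogen in a ring, and a ring nitrogen enters with pyridin-2-yl. Against two of the carbon-only rings this exchange cannot be told from no change: a 1.8-fold higher number from compound 2 to compound 4 (0.26 log units; within the scatter) and a 1.6-fold higher number from compound 3 to compound 4 (0.19 log units; within the scatter) are both printed as within the scatter. Only a 2.5-fold higher number from compound 1 to compound 4 (0.40 log units; beyond the scatter) passes the scatter, and modestly, so this position now shows its first separation between two compounds, limited to 4-methoxyphenyl against pyridin-2-yl, and nothing shown accounts for it.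

The compounds shown leave open whether that separation belongs to the ring nitrogen or to the loss of a substituent on the ring, as pyridin-2-yl carries none and all three carbon-only rings carry one. Unsubstituted phenyl, pyridin-3-yl or pyridin-4-yl on the same nitrogen would address this, and an amine or a carboxylic acid on the ring would test whether the position tolerates a wider range of groups.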